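Shifting One Chlorine on the Hydrazone Aryl Ring

A few compounds are considered here, and "the series" means these few. Any claim that something is new, unique, unknown or untested is made for them only; others in the source may bear on it.

Going by the values given here, compound 3 `COc1cc(C(=O)N/N=C/c2ccc(Cl)c(Cl)c2)cc(OC)c1OC` gives 32.7% in a functional assay on BGC-823 cells (Homo sapiens) for antiproliferative activity, read by MTT assay, tested at 5 uM (on this read-out lower numbers stand for a weaker effect and higher numbers for a stronger effect at the one concentration tested), the lowest of the three numbers known so far. Compound 1 `COc1cc(C(=O)N/N=C/c2ccc(F)c(F)c2)cc(OC)c1OC` gives 51.9%, and compound 2 `COc1cc(C(=O)N/N=C/c2ccccc2F)cc(OC)c1OC` gives 76.5%; the step of a number 19.2 percentage points lower from compound 1 to compound 3 (beyond the scatter) and the step of a number 43.8 percentage points lower from compound 2 to compound 3 (beyond the scatter) both end at compound 3, and both are beyond the scatter. Compound 4 `COc1cc(C(=O)N/N=C/c2cc(Cl)cc(Cl)c2)cc(OC)c1OC` differs from compound 3 by 3,5-dichlorophenyl in place of 3,4-dichlorophenyl on a carbon with a double bond to nitrogen. Among the compounds with values here, no measured step moves a chlorine from one site on this ring to another, so there is no direct guide; the only anchor is that compound 3 stands at the bottom of the range. Compound 4 is therefore expected to show a step of a number 5.3 percentage points higher from compound 3 to compound 4 (within the scatter), not clearly beyond the scatter. Compound 4 is estimated at 38%, between 20% and 58%.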

Compound 4, a percentage reported as inhibition, at one concentration (the size of the read-out at that concentration, not a potency): 9.2%
Estimate against measurement, compound 4: 28.8 percentage points above; the whole stated range lies above it.
By their numbers in this assay, from the lowest: compound 4; then compound 3; then compound 1; then compound 2.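

In this assay the two dichlorophenyl groups carry the same atoms, yet the change gives a number 23.5 percentage points lower from compound 3 to compound 4 (beyond the scatter) and so shows that the arrangement of the chlorines on this ring alters the read-out, not only their presence. The fluorinated comparisons widen with this arrangement, giving a number 42.7 percentage points lower from compound 1 to compound 4 (beyond the scatter) and a number 67.3 percentage points lower from compound 2 to compound 4 (beyond the scatter) in the same assay. No measurement available here accounts for these drops. On these data alone, whether a 2-chlorophenyl group would behave like the 2-fluorophenyl group stays open, as does the effect of an amine or a carboxylic acid on this ring.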